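Trifluoromethyl in place of isopropyl: an expected inhibition

The compounds below may be only part of what the source reports. "The series", "measured", "known", "first", "only" and "open" are said of these compounds alone.

Measured compounds:
compound 1, `COc1ccc(-c2nc(CCO)sc2-c2ccc(OC)cc2)cc1`, 79%
compound 2, `COc1ccc(-c2nc(C(C)C)sc2-c2ccc(OC)cc2)cc1`, 85%

Both were tested in a functional assay on the whole organism for inhibition, with Cavia porcellus as the target, at a dose of 5 mg/kg by the oral route; on this read-out higher numbers stand for a stronger effect at the one dose given and lower numbers for a weaker effect. Of the two numbers compound 2 carries the higher one, yet only within the scatter, as the step of a number 6 percentage points higher from compound 1 to compound 2 (within the scatter) shows. Compound 3, `COc1ccc(-c2nc(C(F)(F)F)sc2-c2ccc(OC)cc2)cc1`, differs from compound 2 by trifluoromethyl in place of isopropyl on an aromatic carbon. Among the compounds with values here, the only measured step that bears on this, a number 6 percentage points higher from compound 1 to compound 2 (within the scatter), also swapped the group on that same aromatic carbon and stayed within the scatter. A step of similar size is therefore expected: a number 5 percentage points lower from compound 2 to compound 3 (within the scatter), no change beyond the scatter. For compound 3 the estimate is 80%, within 65% to 92%.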

Compound 3, a percentage reported as inhibition, in the whole organism at one dose (the size of the read-out at that dose, not a potency): 100%
Compound 3: the middle estimate sits 20 percentage points below what was measured, outside the stated range (above it).
By their numbers in this assay, from the lowest: compounds 1 and 2 (each within the scatter of the next); then compound 3.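

Changing the group on this aromatic carbon can shift the read-out after all: in this assay, trifluoromethyl gives a number 15 percentage points higher from compound 2 to compound 3 (beyond the scatter) and a number 21 percentage points higher from compound 1 to compound 3 (beyond the scatter), whereas the earlier swap of 2-hydroxyethyl for isopropyl gave no change beyond the scatter. This response is tied to one dose, so it shows a larger effect at that dose, not a greater potency. Nothing available explains why trifluoromethyl stands apart from the other two groups.

Going by these compounds, whether a methyl group, an amine or a carboxylic acid on this carbon would match trifluoromethyl remains open. So does how compound 3 would compare with compound 2 at lower doses.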